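The source may hold more compounds than are shown below. What is called first, only, known or untested is meant among the compounds shown, and "the series" means these compounds.

Compound 1 `COC(=O)C1(c2ccccc2)CC1CN1CCN(c2ncccn2)CC1`: 3090 nM in an assay for displacement of a labelled ligand from Sigma non-opioid intracellular receptor 1 (Cavia porcellus); a higher number here means a weaker inhibitor, a lower number a stronger inhibitor; compound 2 `COC(=O)C1(c2ccc(C)cc2)CC1CN1CCN(c2ncccn2)CC1`: 353 nM in this assay.

Compound 2 holds the lower of the two numbers, and the step of an 8.8-fold lower number from compound 1 to compound 2 (0.94 log units; beyond the scatter) shows that a group on this aromatic carbon matters. Compound 3 `COC(=O)C1(c2ccc(N)cc2)CC1CN1CCN(c2ncccn2)CC1` differs from compound 2 by amino in place of methyl on an aromatic carbon. Within the data shown here, only that one step bears on the change, and it concerns a different group, so the direction is uncertain; a modest rise toward the number of compound 1 is expected, since amino is not methyl. For compound 3 an estimate of 1500 nM is given, between 400 nM and 6000 nM, meaning a 4.2-fold higher number from compound 2 to compound 3 (0.63 log units; beyond the scatter).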

Compound 3, inhibition constant: > 10000 nM
Compound 3 gave a limit, no number; the forecaster's own chance of this, stated with the estimate: 5%; middle value at least 6.6-fold (0.82 log units) away from the limit.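

Compound 3 yields a limit of the assay, not a number: the limit of > 10000 nM in this assay, at which 1 of the 3 values shown sits. Amino in place of methyl gives an at least 28-fold higher number from compound 2 to compound 3 (1.45 log units; beyond the scatter), so the gain seen with methyl does not extend to amino at this aromatic carbon. Amino in place of hydrogen gives an at least 3.2-fold higher number from compound 1 to compound 3 (0.51 log units; beyond the scatter), which shows that a group here can move the number in either direction, not only lower it.

Going by these compounds, the actual number for compound 3 remains unknown. On these data alone, whether a methoxy group or a chlorine atom on this carbon would follow methyl or amino also stays open.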